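Swapping a Pyrrolidinylcarbonyl for a 2-Methylphenyl Group

A few compounds are considered here, and "the series" means these few. Any claim that something is new, unique, unknown or untested is made for them only; others in the source may bear on it.

Compound 2 `Cc1cc(C)c(Oc2cc(Nc3ccc(C#N)cc3)ncc2C(=O)NCc2cn(CC(=O)N3CCCC3)nn2)c(C)c1` holds the higher of the two numbers measured in an ADME assay on MT4 cells (Homo sapiens) for cytotoxicity, read by MTT assay, with a stated time of 5 days (on this read-out higher numbers stand for lower toxicity in this test and lower numbers for higher toxicity in this test), giving 58100 nM, whereas compound 1 `COC(=O)Cn1cc(CNC(=O)c2cnc(Nc3ccc(C#N)cc3)cc2Oc2c(C)cc(C)cc2C)nn1` gives 13800 nM. Going by the values given here, the only measured step, a 4.2-fold higher number from compound 1 to compound 2 (0.62 log units; beyond the scatter), changed the same arm of the shared core, so this region clearly moves the read-out. Compound 3 `Cc1cc(C)c(Oc2cc(Nc3ccc(C#N)cc3)ncc2C(=O)NCc2cn(Cc3ccccc3C)nn2)c(C)c1` arises from compound 2 by 2-methylphenyl in place of (pyrrolidin-1-yl)carbonyl on a saturated chain carbon bound to an aromatic nitrogen. Among the compounds with values here, no measured step covers this exact change, so the direction is uncertain. A modest step is expected, a 2.3-fold lower number from compound 2 to compound 3 (0.37 log units; beyond the scatter). For compound 3 the estimated value is 25000 nM, within 8000 nM to 80000 nM.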

Compound 3, half-maximal cytotoxic concentration: >= 164000 nM
Compound 3 was reported as a limit; the forecaster's own chance of this, stated with the estimate: 10%; at least 6.5-fold (0.81 log units) between middle value and limit.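

In this assay compound 3 is reported only as a limit, not as a number: the limit of >= 164000 nM in this assay, at which 1 of the 3 values shown sits.

Putting 2-methylphenyl on the saturated chain carbon bound to an aromatic nitrogen gives an at least 2.8-fold higher number from compound 2 to compound 3 (0.45 log units; beyond the scatter), and set against the methoxycarbonyl it gives an at least 11-fold higher number from compound 1 to compound 3 (1.07 log units; beyond the scatter). Both earlier compounds carry a carbonyl on this arm, so only this result shows that a ring of carbon only, with no hydrogen-bond acceptor, leaves the number no lower.

As far as these compounds go, how far compound 3 lies past its limit stays open. So does whether the methyl of 2-methylphenyl matters, or how a plain benzyl, an amine or a carboxylic acid would read at this place.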